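The source may hold more compounds than are shown below. What is called first, only, known or untested is meant among the compounds shown, and "the series" means these compounds.

Compound 1, `CC(C)=CCC/C(C)=C/CC1Cc2c(OCCCNS(=O)(=O)c3ccc([N+](=O)[O-])cc3)cc(=O)n(CCCO)c2CC1(C)C`: 0%
Compound 2, `CC(C)=CCC/C(C)=C/CC1Cc2c(OCCCNC(=O)c3cccs3)cc(=O)n(CCCO)c2CC1(C)C`: 11.5%
Compound 3, `CC(C)=CCC/C(C)=C/CC1Cc2c(OCCCNC(=O)c3ccc([N+](=O)[O-])cc3)cc(=O)n(CCCO)c2CC1(C)C`: 6.5%

All three compounds were tested in a functional assay on PANC-1 cells (Homo sapiens) for inhibition, read by MTT assay, with a stated time of 24 h, tested at 10 uM (a higher number here means more inhibition at the concentration tested (going by the name of the read-out), a lower number less inhibition), and all three return small numbers. Compound 2 stands apart from compound 1 by a number 11.5 percentage points higher from compound 1 to compound 2 (beyond the scatter), while its distance to compound 3 is a number 5 percentage points lower from compound 2 to compound 3 (within the scatter), so compound 2 and compound 3 cannot be set apart. Compound 1 and compound 3 differ by a number 6.5 percentage points higher from compound 1 to compound 3 (within the scatter).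

The next compound, compound 4, `CC(C)=CCC/C(C)=C/CC1Cc2c(OC(=O)Nc3ccc(F)c(F)c3)cc(=O)n(CCCO)c2CC1(C)C`, is reached from compound 2 by (3,4-difluorophenyl)carbamoyl in place of 3-(((thiophen-2-yl)carbonyl)amino)propyl on an oxygen on an aromatic ring. The three measured steps all concern the group on the amine nitrogen, or on the carbonyl carbon, within the chain that compound 4 no longer carries, so none of them bears directly on this change. What they do show is that varying that end of the chain moved the number by at most a modest amount and never lifted it far from zero. Compound 4 is therefore expected to stay in the same low region, with a step of a number 1.5 percentage points lower from compound 2 to compound 4 (within the scatter) from compound 2, which is not expected to exceed the scatter. For compound 4 the estimate in this assay is 10%, with a range from 0% to 30%.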

Compound 4, a percentage reported as inhibition, at one concentration (the size of the read-out at that concentration, not a potency): 4.8%
Estimate against measurement, compound 4: 5.2 percentage points above; measured number inside the range.
By their numbers in this assay, from the lowest: compounds 1, 4, 3 and 2 (each within the scatter of the next, the first and the last beyond it).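

In this assay, (3,4-difluorophenyl)carbamoyl in place of 3-(((thiophen-2-yl)carbonyl)amino)propyl gives a number 6.7 percentage points lower from compound 2 to compound 4 (within the scatter) and so shows that the group on this oxygen can be exchanged whole while the number stays inside the scatter. The earlier steps shown here varied only the far end of the chain, whereas this one removes the chain, its amide and the five-membered aromatic ring together and brings in a carbamoyl with a six-membered aromatic ring of carbon only, and even this larger change leaves the result in the same low region. No evidence is available that explains this outcome.

Going by these compounds, whether an amine, a carboxylic acid or a longer chain on this oxygen would lift the number clear of that low region remains open. All four compounds also share the same core and the same groups outside the exchanged part, so what those parts contribute to the small numbers is open as well.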